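Alpha-Fluoro Replacement in a Tetrazolyl Acetamide Series

This account rests on a few compounds, and the source may have more. Where it says the series, first, only, none or still open, it means among the compounds named here.

Measured compounds:
compound 1, `CCCCCCCCCCCCn1nnc(C(C(=O)Nc2ccc(F)cc2F)c2ccccc2)n1`, 31 nM
compound 2, `CCCCCCCCCCCCn1nnc(C(C(=O)Nc2ccc3c(C)cc(C)nc3n2)c2ccccc2)n1`, 1540 nM
compound 3, `CCCCCCCCCCCCn1nnc(C(C(=O)Nc2c(OC)cc(OC)cc2OC)c2ccc(N(C)C)cc2)n1`, 659 nM

In an assay on liver for inhibition of sterol O-acyltransferase 1 (Rattus norvegicus), using microsomes (on this read-out lower numbers stand for stronger inhibition and higher numbers for weaker inhibition), compound 3 stands second highest of the three numbers. Its nearest neighbour is compound 2, from which it lies a moderate distance, and its furthest is compound 1, whose number is far lower. For the measured compounds named here, the only single-point step among the measured compounds is a 50-fold higher number from compound 1 to compound 2 (1.70 log units; beyond the scatter), which concerns the aryl group on the amide-type nitrogen and not the carbon that carries the aryl group.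

Compound 4, `CCCCCCCCCCCCn1nnc(C(F)C(=O)Nc2c(OC)cc(OC)cc2OC)n1`, differs from compound 3 by fluoro in place of 4-(dimethylamino)phenyl on a saturated chain carbon bound to an aromatic carbon and a carbonyl carbon. Going by the values given here, no measured step touches this position, since compound 1, compound 2 and compound 3 all keep an aromatic ring there. The expectation for compound 4 therefore rests on the absence of any comparison and is uncertain; a weaker result is expected, as a 3.0-fold higher number from compound 3 to compound 4 (0.48 log units; beyond the scatter). Compound 4 is estimated at 2000 nM, within a range from 400 nM to 10000 nM.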

Compound 4, half-maximal inhibitory concentration: 1760 nM
Compound 4: middle estimate off by 1.1-fold (0.06 log units), on the high side, within the range that was stated.
By their numbers in this assay, from the lowest: compound 1; then compound 3; then compounds 2 and 4 (each within the scatter of the next).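

In this assay, for the compounds shown here, the change on the saturated chain carbon bound to an aromatic carbon and a carbonyl carbon gives a 2.7-fold higher number from compound 3 to compound 4 (0.43 log units; beyond the scatter) and is the first reading at this position. It shows that 4-(dimethylamino)phenyl, with its aromatic ring, can give way to fluoro at a modest cost, and that compound 4 still gives a measurable 1760 nM without any aromatic ring at this position. No measurement available here accounts for the size of this step.

The compounds shown do not separate the loss of the ring from the gain of fluoro, which a methyl group or a hydroxyl group on the same carbon could help to do. Going by these compounds, it also remains open whether fluoro at this position gives a similar step with other groups on the amide-type nitrogen.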